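One bromo added to compound 2: expected cytotoxicity shift

A few compounds are considered here, and "the series" means these few. Any claim that something is new, unique, unknown or untested is made for them only; others in the source may bear on it.

In an ADME assay on HEK293 cells (Homo sapiens) for cytotoxicity, read by reporter gene assay and resazurin assay, with a stated time of 48 h (on this read-out lower numbers stand for higher toxicity in this test and higher numbers for lower toxicity in this test), compound 2 `O=C(Nc1cccc(Cl)c1)c1ccccc1O` gives 37000 nM, the highest of the two true numbers in this small set. Compound 1 `O=C(Nc1cccc(Cl)c1)c1cc(Br)cc(Br)c1O` gives 18000 nM, a lower number by a margin beyond the scatter. Compound 3 `COc1ccccc1C(=O)Nc1cccc(Cl)c1` gives > 100000 nM, which is a limit of the assay and not a number.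

Compound 4 `O=C(Nc1cccc(Cl)c1)c1cccc(Br)c1O` differs from compound 2 by a single change: bromo in place of hydrogen on an aromatic carbon. In words, this is bromo in place of hydrogen on an aromatic carbon, ortho to a hydroxy group.

Within the data shown here, the only measured step in one place, an at least 2.7-fold higher number from compound 2 to compound 3 (0.43 log units; beyond the scatter), changes the oxygen and not a ring carbon, so it gives little guidance on size here. Compound 1 is the closer guide: it holds this bromo and a further one, and it stands at 18000 nM. Compound 4 is therefore expected to fall near or between the values of compound 2 and compound 1, on the side of higher toxicity in this assay. The expected step is small, a 1.5-fold lower number from compound 2 to compound 4 (0.17 log units; within the scatter), and no large shift is anticipated. For compound 4 the estimate is 25000 nM, with an expected range of 12000 nM to 50000 nM.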

Compound 4, half-maximal cytotoxic concentration: 32000 nM
Compound 4: the middle estimate sits 1.3-fold (0.11 log units) below what was measured; the measured number falls inside the stated range.
By their numbers in this assay, from the lowest: compounds 1, 4 and 2 (each within the scatter of the next, the first and the last beyond it). At a limit, above all of these: compound 3.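

In this assay, bromo in place of hydrogen on this aromatic carbon, ortho to a hydroxy group, gives a 1.2-fold lower number from compound 2 to compound 4 (0.06 log units; within the scatter) and so leaves the read-out within the usual scatter. Compound 1 carries this bromo and a further one, so on its own it could not show what this single bromo contributes. The one-place step that removes the further bromo gives a 1.8-fold higher number from compound 1 to compound 4 (0.25 log units; within the scatter) and is also within the scatter, which means that neither single step separates compound 4 from the compound it is paired with.

Still open, from the compounds shown here alone, is how a compound carrying only the further bromo would read, and whether an amine, a carboxylic acid or a longer chain on this same carbon would stay within the scatter of compound 2. Nothing shown here bears on why these two steps are as small as they are.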